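Extending the Chain of Compound 3

The compounds below may be only part of what the source reports. "The series", "measured", "known", "first", "only" and "open" are said of these compounds alone.

Measured in an ADME assay on cells (Peritoneal macrophage, Mus musculus) for cytotoxicity, read by CCK-8 assay, with a stated time of 24 h; on this read-out higher numbers stand for lower toxicity in this test and lower numbers for higher toxicity in this test:
- Compound 1 `COc1ccc(S(=O)(=O)N(CC(N)=O)c2ccc(N(CC(N)=O)S(=O)(=O)c3ccc(SCCCCCN=C=S)cc3)c3ccccc23)cc1`: > 10000 nM
- Compound 2 `COc1ccc(S(=O)(=O)N(CC(N)=O)c2ccc(N(CC(N)=O)S(=O)(=O)c3ccc(SCCOCCN=C=S)cc3)c3ccccc23)cc1`: > 10000 nM
- Compound 3 `COc1ccc(S(=O)(=O)N(CC(N)=O)c2ccc(N(CC(N)=O)S(=O)(=O)c3ccc(SCCOCCOCCN=C=S)cc3)c3ccccc23)cc1`: > 10000 nM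

Compound 3 stands at > 10000 nM, which is a limit and not a number. The other two entries are limits as well, and the overall picture is the limit of > 10000 nM in this assay, at which 3 of the 3 values shown sit.

Compound 4 `COc1ccc(S(=O)(=O)N(CC(N)=O)c2ccc(N(CC(N)=O)S(=O)(=O)c3ccc(SCCOCCOCCOCCN=C=S)cc3)c3ccccc23)cc1` differs from compound 3 by a single change: a group of 6 heavy atoms (3 carbon, 1 nitrogen, 1 oxygen, 1 sulfur; no ring) in place of a group of 3 heavy atoms (1 carbon, 1 nitrogen, 1 sulfur; no ring), on a saturated chain carbon, two bonds along the chain from an oxygen on a saturated carbon. For the measured compounds named here, the closest precedent is a step that the two limits leave unreadable from compound 2 to compound 3, which shows the same exchange of groups at the same kind of place. Two more steps bear on it, a step that the two limits leave unreadable from compound 1 to compound 2 and a step that the two limits leave unreadable from compound 1 to compound 3. Going by the values given here, none of these three steps has a readable size, so they offer only the fact that no compound so far has left the limit.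

In this assay, no step beyond the usual scatter is expected, in either direction. The estimated step is a step that the limit leaves unreadable from compound 3 to compound 4. The result will most likely be reported as a limit again. For compound 4 the estimated value is 15000 nM, with an expected range from 10000 nM to 40000 nM.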

Compound 4, half-maximal cytotoxic concentration: > 10000 nM
Compound 4: only a limit was reported; the forecaster's own chance of this, stated with the estimate: 90%; the middle value does not contradict the limit.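

In this assay compound 4 gives > 10000 nM, which is a limit and not a number. None of the steps from compound 1, compound 2 or compound 3 to compound 4 can be read, and all four compounds share one limit: the limit of > 10000 nM in this assay, at which 4 of the 4 values shown sit.

The compounds shown leave open whether the length of the chain changes the cytotoxic concentration at all in this assay.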